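Swapping the Imidazolyl Cap for an Oxadiazolyl Group

The source may report more compounds than this note shows. Statements on the series, on what has been measured and on what is new or still open speak of the compounds shown alone.

Of the compounds shown here, three sharing one core have been measured in an assay on brain for displacement of a labelled ligand from D(3) dopamine receptor (Rattus norvegicus); a lower number here means a stronger inhibitor, a higher number a weaker inhibitor. Compound 1 `CCCN(CC[C@H]1CC[C@H](NC(=O)/C=C/c2ccc(OC)cc2)CC1)[C@H]1CCc2nc(N)sc2C1` gives 6.7 nM. Compound 2 `CCCN(CC[C@H]1CC[C@H](NC(=O)c2ccc3ccccc3n2)CC1)[C@H]1CCc2nc(N)sc2C1` gives 1.6 nM, and compound 3 `CCCN(CC[C@H]1CC[C@H](NC(=O)c2ccc(-n3ccnc3)cc2)CC1)[C@H]1CCc2nc(N)sc2C1` gives 1.9 nM. Compound 3 thus holds the second highest of the three numbers; it sits closest to compound 2, separated by a 1.2-fold higher number from compound 2 to compound 3 (0.07 log units; within the scatter), and furthest from compound 1, separated by a 3.5-fold lower number from compound 1 to compound 3 (0.55 log units; beyond the scatter). The remaining step, a 4.2-fold lower number from compound 1 to compound 2 (0.62 log units; beyond the scatter), is of similar size to that last one.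

Compound 4 `CCCN(CC[C@H]1CC[C@H](NC(=O)c2ccc(-c3noc(C(C)C)n3)cc2)CC1)[C@H]1CCc2nc(N)sc2C1` differs from compound 3 in one place: 5-isopropyl-1,2,4-oxadiazol-3-yl in place of 1H-imidazol-1-yl on an aromatic carbon. Going by the values given here, no measured step exchanges one five-membered ring for another on this aromatic carbon. The step that bears most closely on it, a 1.2-fold higher number from compound 2 to compound 3 (0.07 log units; within the scatter), exchanged one aromatic cap for another and stayed within the scatter, while both larger steps concerned the cap of compound 1. Compound 4 is therefore expected to show a 1.3-fold higher number from compound 3 to compound 4 (0.12 log units; within the scatter), a step within the scatter. In this assay compound 4 is estimated at 2.5 nM, ranging from 0.8 nM to 8 nM.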

Compound 4, inhibition constant: 2 nM
The estimate for compound 4 lay 1.3-fold (0.10 log units) above the measured number, and the stated range covers the measured number.
By their numbers in this assay, from the lowest: compounds 2, 3 and 4 (each within the scatter of the next); then compound 1.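

The only step shown that exchanges one five-membered aromatic ring for another, on the aromatic carbon para to a large group, reads in this assay as a 1.1-fold higher number from compound 3 to compound 4 (0.02 log units; within the scatter). Earlier steps compared only whole caps on the carbonyl carbon, whereas this one alters just the ring at the far end of the cap of compound 3. It shows that this position accepts 5-isopropyl-1,2,4-oxadiazol-3-yl, with more heavy atoms and more hydrogen-bond acceptors than 1H-imidazol-1-yl, without a shift beyond the scatter.

The compounds shown leave open whether this position would hold its number with an amine, a carboxylic acid or a longer alkyl chain on the six-membered aromatic ring in place of a five-membered ring. Nothing available here accounts for the result.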